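The compounds below may be only part of what the source reports. "The series", "measured", "known", "first", "only" and "open" are said of these compounds alone.

In a functional assay on A549 cells (Homo sapiens) for cytotoxicity, read by MTT assay, with a stated time of 48 h (a higher number here means a weaker inhibitor, a lower number a stronger inhibitor), compound 3 `COc1c(OCCCNCc2ccccc2)cc(O)c2c(=O)cc(-c3ccccc3)oc12` gives 1570 nM. Compound 2 `COc1c(OCCCCN2CCCCC2)cc(O)c2c(=O)cc(-c3ccccc3)oc12` gives 1150 nM, and the two sit within the scatter of each other, as a 1.4-fold higher number from compound 2 to compound 3 (0.14 log units; within the scatter) shows. Compound 1 `COc1c(OCc2cnoc2C)cc(O)c2c(=O)cc(-c3ccccc3)oc12` reaches only a limit of the assay, > 100000 nM. The steps away from that limit are large: an at least 86-fold lower number from compound 1 to compound 2 (1.93 log units; beyond the scatter), and an at least 63-fold lower number from compound 1 to compound 3 (1.80 log units; beyond the scatter). Both replace 5-methyl-1,2-oxazol-4-yl, however, so they bear only loosely on the change now in question. Compound 4 `COc1c(OCCCN2CCCC2)cc(O)c2c(=O)cc(-c3ccccc3)oc12` differs from compound 3 as follows: pyrrolidin-1-yl in place of benzylamino on a saturated chain carbon, three bonds along the chain from an oxygen on an aromatic ring. In words, pyrrolidin-1-yl stands in place of benzylamino on a saturated chain carbon, three bonds along the chain from an oxygen on an aromatic ring. Among the measured compounds shown here, the closest precedent is compound 2, where a 1.4-fold higher number from compound 2 to compound 3 (0.14 log units; within the scatter) also involves benzylamino and a saturated ring in its stead, and that step stays within the scatter. On that basis, no step beyond the scatter is expected in this assay, and the expected step is a 1.0-fold lower number from compound 3 to compound 4 (0.02 log units; within the scatter). Compound 4 is estimated at 1500 nM, with an expected range from 550 nM to 4500 nM.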

Compound 4, half-maximal inhibitory concentration: 1390 nM
For compound 4 the middle estimate is 1.1-fold (0.03 log units) above the measured one, and the stated range covers the measured number.
By their numbers in this assay, from the lowest: compounds 2, 4 and 3 (each within the scatter of the next). At a limit, above all of these: compound 1.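

In this assay, pyrrolidin-1-yl replaces benzylamino, so the six-membered aromatic ring and the hydrogen-bond donor both leave, yet a 1.1-fold lower number from compound 3 to compound 4 (0.05 log units; within the scatter) is the whole step. Pyrrolidin-1-yl in place of (piperidin-1-yl)methyl gives a 1.2-fold higher number from compound 2 to compound 4 (0.08 log units; within the scatter), so compounds 2, 3 and 4 read alike across three different amine ends on this chain, whether that end is a saturated ring or an open benzylamino. Compound 1 stands at a limit of the assay, not at a number, so an at least 71-fold lower number from compound 1 to compound 4 (1.85 log units; beyond the scatter) is only a bound: the limit of > 100000 nM in this assay, at which 1 of the 4 values shown sits.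

As far as these compounds go, compound 1 differs from compound 4 in both chain length and end group, so it remains open whether the amine nitrogen or the chain accounts for that gap. These compounds also do not show how a hydroxyl or a morpholin-4-yl at the chain end would read.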